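The source may hold more compounds than are shown below. What is called first, only, known or untested is meant among the compounds shown, and "the series" means these compounds.

Among the measured compounds shown here, in a functional assay on MCF7 cells (Homo sapiens) for cytotoxicity, read by MTT assay, with a stated time of 48 h (on this read-out higher numbers stand for weaker inhibition and lower numbers for stronger inhibition), three compounds have numbers so far: compound 1 (`C=C1CCC[C@]2(C)CCC(C=O)=CC[C@@]12C`) gives 319000 nM as its value, compound 2 (`C#CC1=CC[C@]2(CC1)C(=C)CC[C@H]2C(C)C`) gives 135000 nM and compound 3 (`C=C1CCC[C@]2(C)CCC(c3cn(-c4ccc(I)cc4)nn3)=CC[C@@]12C`) gives 162000 nM on the same read-out. Compound 3 lies within the scatter of both compound 2 and compound 1, so these numbers give it no separate rank. Compound 4 (`C=C1CCC[C@]2(C)CCC(c3cn(-c4ccc(C)cc4)nn3)=CC[C@@]12C`) differs from compound 3 in one place (methyl in place of iodo on an aromatic carbon): methyl in place of iodo on an aromatic carbon, para to a large group, so that 4-iodophenyl becomes 4-methylphenyl. For the measured compounds named here, no measured pair differs in one place, so no measured step gives a size for this change. The estimate therefore rests on compound 3 at 162000 nM as the closest measured structure. What is expected in this assay is a 1.1-fold lower number from compound 3 to compound 4 (0.03 log units; within the scatter) and nothing beyond the scatter, with neither direction favoured. Compound 4 is estimated at 150000 nM with an expected range from 70000 nM to 320000 nM on this read-out.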

Compound 4, half-maximal inhibitory concentration: 54900 nM
Beside the measured number, compound 4's estimate is 2.7-fold (0.44 log units) above it; measured number outside the range, below it.
By their numbers in this assay, from the lowest: compound 4; then compounds 2, 3 and 1 (each within the scatter of the next, the first and the last beyond it).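

In this assay, among the compounds shown here, methyl in place of iodo on an aromatic carbon, para to a large group, gives a 3.0-fold lower number from compound 3 to compound 4 (0.47 log units; beyond the scatter) and so provides the first single-place step. This shows that the number responds to the group at this position, with 4-methylphenyl giving a lower number than 4-iodophenyl by a modest step beyond the scatter. Nothing available explains this step.

One step cannot show whether the lower number is specific to methyl or would follow other replacements of iodo at this carbon. As far as these compounds go, an amine, a carboxylic acid or a longer chain such as propyl at the same place could extend the comparison, and the step's size and direction for those groups remain open.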